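Adding one fluoro to compound 2

The compounds below may be only part of what the source reports. "The series", "measured", "known", "first", "only" and "open" are said of these compounds alone.

In an ADME assay on L6 cells (Rattus norvegicus) for cytotoxicity, read by resazurin assay (a higher number here means a weaker inhibitor, a lower number a stronger inhibitor), compound 1 (`N=C(N)c1ccc2[nH]c(-c3ccc4nc(-c5ccccc5F)[nH]c4c3)nc2c1`) gives 26.8 ug/mL. Compound 2 (`N=C(N)c1ccc2[nH]c(-c3ccc4nc(-c5ccccc5Oc5ccc(Cl)cc5)[nH]c4c3)nc2c1`) gives > 90 ug/mL, and this is a limit of the assay and not a number. Within the data shown here, only one measured step bears on what follows: an at least 3.3-fold higher number from compound 1 to compound 2 (0.52 log units; beyond the scatter). That step replaced fluoro with a 4-chlorophenoxy group, which is a much larger exchange than the one now in question.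

Compound 3 (`N=C(N)c1ccc2[nH]c(-c3ccc4nc(-c5cc(F)ccc5Oc5ccc(Cl)cc5)[nH]c4c3)nc2c1`) keeps the whole of compound 2 except for one change: fluoro in place of hydrogen on an aromatic carbon. The new fluoro sits para to a 4-chlorophenoxy group. Among the measured compounds shown here, no measured pair makes this same exchange, so its size has to be judged indirectly. A single fluoro for hydrogen is a far smaller edit than the step from 26.8 ug/mL in compound 1, so no step beyond the scatter is expected. The expected step is an at least 1.0-fold lower number from compound 2 to compound 3 (0.02 log units; that floor lies within the scatter). Compound 3 is estimated at 85 ug/mL, with an expected range from 45 ug/mL to 130 ug/mL.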

Compound 3, half-maximal inhibitory concentration: > 90 ug/mL
Compound 3: no number, only a limit; the forecaster's own chance of this, stated with the estimate: 50%; middle value at least 1.0-fold (0.02 log units) away from the limit.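

In this assay compound 3 gives > 90 ug/mL, which is a limit of the assay and not a number. Compound 2 gives > 90 ug/mL, also a limit. No step between compound 2 and compound 3 can therefore be read: the limit of > 90 ug/mL in this assay, at which 2 of the 3 values shown sit.

The compounds shown leave open whether fluoro in place of hydrogen shifts the number in this assay at all.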